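Aryloxy variation on the shared core: methyl for fluoro

The source may report more compounds than this note shows. Statements on the series, on what has been measured and on what is new or still open speak of the compounds shown alone.

The series keeps one core and varies the aryl ring on its oxygen. Compound 1 `Cc1nnsc1CO/N=C/c1c(C)nn(C)c1Oc1ccccc1Cl` carries a 2-chlorophenyl group, compound 2 `Cc1nnsc1CO/N=C/c1c(C)nn(C)c1Oc1cccc(F)c1` a 3-fluorophenyl group, and compound 3 `Cc1nnsc1CO/N=C/c1c(C)nn(C)c1Oc1ccc(I)cc1` a 4-iodophenyl group. In a functional assay on SGC-7901 cells (Homo sapiens) for inhibition, read by MTT assay, with a stated time of 48 h (a lower number here means a stronger inhibitor, a higher number a weaker inhibitor), compound 1 gives > 50000 nM, which is a limit of the assay and not a number. In this assay compound 2 gives > 50000 nM, also a limit. In this assay compound 3 gives > 50000 nM, again a limit. The steps a step that the two limits leave unreadable from compound 1 to compound 2, a step that the two limits leave unreadable from compound 1 to compound 3 and a step that the two limits leave unreadable from compound 2 to compound 3 therefore cannot be sized; what the data show is the limit of > 50000 nM in this assay, at which 3 of the 3 values shown sit.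

Compound 4 `Cc1cccc(Oc2c(/C=N/OCc3snnc3C)c(C)nn2C)c1` is not yet measured. It differs from compound 2 by methyl in place of fluoro on an aromatic carbon. For the measured compounds named here, no measured step covers this change directly, and the nearest pairs, compound 1 to compound 2 and compound 2 to compound 3, are both unreadable. With no readable step in this assay, no direction beyond the scatter can be claimed. Compound 4 is accordingly expected to give 70000 nM in this assay, with a range from 20000 nM to 250000 nM, and most probably a limit rather than a number. The step from compound 2 to compound 4 implied by this estimate is expected to be a step that the limit leaves unreadable from compound 2 to compound 4.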

Compound 4, half-maximal inhibitory concentration: 12800 nM
Compound 4: the middle estimate sits 5.5-fold (0.74 log units) above what was measured; measured number outside the range, below it.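

In this assay, for the compounds shown here, methyl in place of fluoro on an aromatic carbon, meta to a large group, gives the first readable step at this position: an at least 3.9-fold lower number from compound 2 to compound 4 (0.59 log units; beyond the scatter). The 3-methylphenyl group also separates from the other two aryl groups, with 3-methylphenyl in place of 4-iodophenyl giving an at least 3.9-fold lower number from compound 3 to compound 4 (0.59 log units; beyond the scatter) and 3-methylphenyl in place of 2-chlorophenyl giving an at least 3.9-fold lower number from compound 1 to compound 4 (0.59 log units; beyond the scatter). The aryl group on the oxygen can therefore bring this read-out to a number, and on this ring the exchange of one heavy atom is enough, while the three halogen-bearing aryl groups remain at the assay's limit: the limit of > 50000 nM in this assay, at which 3 of the 4 values shown sit.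

The steps among compound 1, compound 2 and compound 3 cannot be read, and in these compounds the place of the aryl substituent is not separated from its identity. As far as these compounds go, whether an ethyl, a methoxy, an amine or a carboxylic acid at the place of the methyl would take the number lower still or return it to the limit stays open.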